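The source may hold more compounds than are shown below. What is called first, only, known or untested is meant among the compounds shown, and "the series" means these compounds.

Cytotoxicity series on the shared amide core. Compound 1 `O=C(Nc1cccc(Oc2ccccc2)c1)C1CCCN(C(=O)c2cccc(-c3ccco3)c2)C1` and compound 2 `Cc1nc(-c2cccc(C(=O)N3CCCC(C(=O)Nc4ccc(Cl)cc4)C3)c2)no1` have both been tested in an ADME assay on PC-3 cells (Homo sapiens) for cytotoxicity, read by WST assay, tested at 100 uM; on this read-out lower numbers stand for less inhibition and higher numbers for more inhibition at the one concentration tested (going by the name of the read-out). There compound 1 gives 0%, and compound 2 gives 0%, which leaves compound 2 level with compound 1 within the scatter. Compound 3 `COc1cccc(C(=O)N2CCCC(C(=O)Nc3ccc(Cl)cc3)C2)c1` is not yet measured; it differs from compound 2 by methoxy in place of 5-methyl-1,2,4-oxadiazol-3-yl on an aromatic carbon. With both measured values at the floor of the read-out, no step beyond the scatter is expected from compound 2 to compound 3 in this assay, estimated as a number 2 percentage points higher from compound 2 to compound 3 (within the scatter). Compound 3 is accordingly expected to give 2%, in the range 0% to 15%.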

Compound 3, a percentage reported as inhibition, at one concentration (the size of the read-out at that concentration, not a potency): 0%
Compound 3: middle estimate off by 2 percentage points, on the high side; the range from low to high includes it.
By their numbers in this assay, from the lowest: compounds 1, 2 and 3 (each within the scatter of the next).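

In this assay, methoxy in place of 5-methyl-1,2,4-oxadiazol-3-yl gives no change at the digits printed from compound 2 to compound 3 (within the scatter). This aromatic carbon, meta to a large group, therefore carries either the ring-bearing group or the smaller, ringless methoxy with compound 3 still at 0%. No measured evidence on the reason for this result is at hand.

Open, going by these compounds, is whether an amine or a carboxylic acid on this aromatic carbon would lift the read-out in this assay. With all values shown at the floor, the read-out gives no ranking of groups at this position.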